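Anilino series: dimethylphenyl to fluorophenyl on the shared core

This account rests on a few compounds, and the source may have more. Where it says the series, first, only, none or still open, it means among the compounds named here.

Among the measured compounds shown here, compound 1 `Cc1ccc(NC2=CC(=O)c3c(nc4n3[C@H]3OC[C@@H](O)[C@H]3OC4)C2=O)cc1C` is the one member of this set with a number in a functional assay on ECa-109 cells for inhibition, with ECa-109 cell line (Homo sapiens) as the target, read by sulforhodamine B assay; on this read-out lower numbers stand for stronger inhibition and higher numbers for weaker inhibition; in this assay compound 1 gives 4090 nM. Compound 2 `O=C1C=C(NC2CCCC2)C(=O)c2c1nc1n2[C@H]2OC[C@@H](O)[C@H]2OC1` reaches only a limit of the assay, > 16000 nM. Compound 3 `COc1ccccc1NC1=CC(=O)c2nc3n(c2C1=O)[C@H]1OC[C@@H](O)[C@H]1OC3` likewise reaches only a limit of the assay, > 4000 nM. For the measured compounds named here, the one step that changes a single place, from compound 2 to compound 3, a step that the two limits leave unreadable from compound 2 to compound 3, cannot be sized; both of its ends sit at a limit, the limit of > 16000 nM in this assay, at which 1 of the 3 values shown sits, and (the limit of > 4000 nM in this assay, at which 1 of the 3 values shown sits), so no direction can be read from it.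

Compound 4 `O=C1C(Nc2cccc(F)c2)=CC(=O)c2c1nc1n2[C@H]2OC[C@@H](O)[C@H]2OC1` differs from compound 1 by 3-fluorophenyl in place of 3,4-dimethylphenyl on an amine nitrogen. Going by the values given here, no measured step with a readable size shares this change, and the only measured step with one difference gives no number. The expectation for compound 4 therefore rests on compound 1 alone, with both substituents being single six-membered aromatic rings of carbon on the same amine nitrogen: a step of about a 1.5-fold higher number from compound 1 to compound 4 (0.17 log units; within the scatter), not beyond the usual scatter, is expected, with a real chance that the assay returns only a limit. In this assay compound 4 is estimated at 6000 nM, within a range from 2000 nM to 20000 nM.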

Compound 4, half-maximal inhibitory concentration: 2370 nM
For compound 4 the middle estimate is 2.5-fold (0.40 log units) above the measured one, and the stated range covers the measured number.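

In this assay, among the compounds shown here, the series now has its first readable step on the amine nitrogen, a 1.7-fold lower number from compound 1 to compound 4 (0.24 log units; within the scatter), whereas the only earlier step had no readable size. On an amine nitrogen whose other neighbours are a double-bonded ring carbon, 3,4-dimethylphenyl and 3-fluorophenyl, each a single six-membered aromatic ring of carbon, cannot be told apart on this read-out, and this one pair sets no trend for other rings at this position. Nothing measured here bears on a cause for this step.

As far as these compounds go, the 2-methoxyphenyl analogue compound 3 gives > 4000 nM, which is only a limit of the assay, so its step from compound 2 cannot be read and the effect of that ring at this position stays open. Also open, from the compounds shown here alone, is what a phenyl ring carrying a carboxylic acid or an aminomethyl group, or a longer alkyl chain in place of the ring, would give on the same amine nitrogen.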